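A few compounds are considered here, and "the series" means these few. Any claim that something is new, unique, unknown or untested is made for them only; others in the source may bear on it.

Values in a functional assay (aorta) for inhibition, with Rattus norvegicus as the target; on this read-out higher numbers stand for weaker inhibition and lower numbers for stronger inhibition:
- compound 1 `CCCC/N=C(\S)[C@]1(c2cccnc2)CCCC[S+]1[O-]`: 8000 nM
- compound 2 `[O-][S+]1CCCC[C@]1(/C(S)=N/c1ccccc1)c1cccnc1`: > 30000 nM (a limit)
- compound 3 `COC(=O)CC/N=C(\S)[C@]1(c2cccnc2)CCCC[S+]1[O-]`: > 30000 nM (a limit)

Compound 3 has no exact number, only the limit > 30000 nM. Compound 4 `N/N=C(\S)[C@]1(c2cccnc2)CCCC[S+]1[O-]` differs from it as follows: amino in place of 2-(methoxycarbonyl)ethyl on a double-bonded nitrogen.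

Going by the values given here, two measured steps bear on this change, an at least 3.7-fold higher number from compound 1 to compound 2 (0.57 log units; beyond the scatter) and an at least 3.7-fold higher number from compound 1 to compound 3 (0.57 log units; beyond the scatter). Both are beyond the scatter and lead to limits, while a step that the two limits leave unreadable from compound 2 to compound 3 cannot be sized. Neither readable step tests amino, so only a modest shift toward stronger inhibition in this assay is expected, and the result may stay at the limit. The expected change is an at least 2.1-fold lower number from compound 3 to compound 4 (0.33 log units; beyond the scatter).

Compound 4 is estimated at 14000 nM, with an expected range of 4000 nM to 40000 nM.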

Compound 4, concentration for 90% inhibition: > 30000 nM
Compound 4: a limit, no number; the forecaster's own chance of this, stated with the estimate: 45%; middle value at least 2.1-fold (0.33 log units) away from the limit.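

In this assay, compound 4 gives only a limit, > 30000 nM, so amino, with its single heavy atom, joins phenyl and 2-(methoxycarbonyl)ethyl on the double-bonded nitrogen without an exact number. Butyl remains the only group shown here with one, and amino in its place gives an at least 3.7-fold higher number from compound 1 to compound 4 (0.57 log units; beyond the scatter). The steps among compound 2, compound 3 and compound 4 cannot be read, and the comparisons end at a single limit: the limit of > 30000 nM in this assay, at which 3 of the 4 values shown sit.

On these data alone, whether any group at this position gives stronger inhibition than butyl stays open. A longer chain such as hexyl or a shorter one such as propyl could show whether chain length matters.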